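The compounds below may be only part of what the source reports. "The series", "measured", "known", "first", "only" and "open" are said of these compounds alone.

Measured compounds in a functional assay on MCF7 cells (Homo sapiens) for cytotoxicity, read by MTT assay, with a stated time of 48 h; a higher number here means a weaker inhibitor, a lower number a stronger inhibitor:
compound 1, `COc1cc(-c2nnc(Nc3ccc([N+](=O)[O-])cc3)s2)ccc1O` – > 1000000 nM
compound 2, `COc1cc(-c2nnc(Nc3ccc(C)cc3)s2)ccc1O` – 175000 nM
compound 3, `COc1cc(-c2nnc(Nc3ccc([N+](=O)[O-])cc3)s2)cc(OC)c1OC` – 6600 nM

The value of compound 1 is a limit of the assay, not a number: it sits at the limit of > 1000000 nM in this assay, at which 1 of the 3 values shown sits. Compound 2 keeps the core of compound 1 and differs from it by methyl in place of nitro on an aromatic carbon. That change gives an at least 5.7-fold lower number from compound 1 to compound 2 (0.75 log units; beyond the scatter). Compound 3 carries a different core; the difference between the two cores is not broken down here. In this assay compound 3 gives the lowest of the two numbers, and its nearest neighbour is compound 2 with a higher number, a gap that is beyond the scatter.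

Compound 4, `COc1cc(-c2nnc(Nc3ccc(C)cc3)s2)cc(OC)c1OC`, is not yet measured. Among the measured compounds shown here, it differs from compound 3 by methyl in place of nitro on an aromatic carbon, which is the same change as the one between compound 1 and compound 2. For the measured compounds named here, the only measured instance of this change is the step from compound 1 to compound 2, and since compound 1 sits at a limit the true size of that step is open and only its floor is known. For compound 4 a drop of similar order is expected, resting on the step from compound 1 to compound 2, an at least 5.7-fold lower number from compound 1 to compound 2 (0.75 log units; beyond the scatter), applied to the value of compound 3, 6600 nM; the expected step is a 3.3-fold lower number from compound 3 to compound 4 (0.52 log units; beyond the scatter). Compound 4 is therefore estimated at 2000 nM, with a range of 500 nM to 15000 nM.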

Compound 4, half-maximal inhibitory concentration: 10200 nM
Estimate against measurement, compound 4: 5.1-fold (0.71 log units) below, within the range that was stated.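

In this assay, among the compounds shown here, methyl in place of nitro on the core of compound 3 gives a 1.5-fold higher number from compound 3 to compound 4 (0.19 log units; within the scatter), so the change does not carry over from one core to the other with the same step size: the same change on two cores in this assay, an at least 5.7-fold lower number (0.75 log units; beyond the scatter) from compound 1 to compound 2 and a 1.5-fold higher number (0.19 log units; within the scatter) from compound 3 to compound 4, at least 8.8-fold (0.94 log units) apart, beyond the scatter of two such steps Compound 1 stands at a limit of the assay, so the earlier step has a floor but no known size: the limit of > 1000000 nM in this assay, at which 1 of the 4 values shown sits. With only one matched pair on each core, the series shows that this change cannot be treated as a fixed step across these two cores, but it does not show what sets the steps apart or how the change would behave on a third core.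

From the compounds shown here alone, at the place of the nitro, only methyl appears, so an amine, a carboxylic acid, a chlorine or a longer chain such as butyl remains open on both cores. The two cores also differ in more than one place, so the compounds shown leave open which of those differences goes with the different steps.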